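Replacing benzyl on the amide-type nitrogen of compound 2

A few compounds are considered here, and "the series" means these few. Any claim that something is new, unique, unknown or untested is made for them only; others in the source may bear on it.

In a functional assay on HCT-116 cells (Homo sapiens) for antiproliferative activity, read by MTT assay, with a stated time of 72 h (a lower number here means a stronger inhibitor, a higher number a weaker inhibitor), compound 1 (`C=CC(=O)Nc1nc(-c2ccc(O)cc2)cs1`) gives 7100 nM as a measured number. Compound 2 (`C=CC(=O)N(Cc1ccccc1)c1nc(-c2ccccc2)cs1`) gives > 30000 nM here, which is a limit of the assay and not a number. Among the compounds with values here, no pair of measured compounds differs in one place, so the series offers no measured size for a change at this position. Compound 3 (`C=CC(=O)N(Cc1cc(C)no1)c1nc(-c2ccccc2)cs1`) carries 3-methyl-1,2-oxazol-5-yl in place of phenyl on a saturated chain carbon bound to an amide-type nitrogen, which also reads as benzyl to (3-methyl-1,2-oxazol-5-yl)methyl. With only a limit as the starting point, a modest gain in this assay is expected, and a second limit remains quite possible. The step expected an at least 1.6-fold lower number from compound 2 to compound 3 (0.22 log units; that floor lies within the scatter) is an estimate and small. For compound 3 the estimated value is 18000 nM (range 5000 nM to 45000 nM).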

Compound 3, half-maximal inhibitory concentration: > 30000 nM
Compound 3 gave a limit, no number; the forecaster's own chance of this, stated with the estimate: 45%; middle value at least 1.6-fold (0.22 log units) away from the limit.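

No step can be read from compound 2 to compound 3, as both give only a limit and not a number in this assay: the limit of > 30000 nM in this assay, at which 2 of the 3 values shown sit.

The compounds shown leave open whether 3-methyl-1,2-oxazol-5-yl in place of phenyl changes antiproliferative activity at all.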